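Hydroxamic Acid Triazoles in an HDAC6 Assay: A Methyl Swap

The source may report more compounds than this note shows. Statements on the series, on what has been measured and on what is new or still open speak of the compounds shown alone.

Measured compounds:
compound 1, `COc1ccc(-c2nc(CNc3ccc(C(=O)NO)cc3)n(-c3ccccc3)n2)cc1`: 77.6%
compound 2, `NNC(=O)c1ccc(NCc2nc(-c3ccccc3)nn2-c2ccccc2)cc1`: 10%

Among the measured compounds shown here, in an assay on Sf9 cells for inhibition of protein deacetylase HDAC6 (Homo sapiens), read by fluorescence, with a stated time of 40 min, tested at 100 nM (on this read-out higher numbers stand for more inhibition at the one concentration tested (going by the name of the read-out) and lower numbers for less inhibition), compound 1 gives 77.6%, the higher of the two numbers known. For the measured compounds named here, its nearest neighbour, compound 2, gives 10% in this assay, a gap that lies beyond the scatter; no single-change step links these two compounds, so only their two values can be compared.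

Compound 3, `Cc1ccccc1-c1nc(CNc2ccc(C(=O)NO)cc2)n(-c2ccccc2)n1`, has not yet been tested. It differs from compound 1 in one place: 2-methylphenyl in place of 4-methoxyphenyl on an aromatic carbon. The hydroxamic acid that compound 2 lacks is kept, so the step is expected to be small, in either direction or none beyond the scatter, with a number 7.6 percentage points lower from compound 1 to compound 3 (within the scatter) as the estimated change. Compound 3 is therefore expected to give about 70% in this assay, within a range of 45% to 90%.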

Compound 3, a percentage reported as inhibition, at one concentration (the size of the read-out at that concentration, not a potency): 53.2%
Compound 3: middle estimate off by 16.8 percentage points, on the high side; the range from low to high includes it.
By their numbers in this assay, from the lowest: compound 2; then compound 3; then compound 1.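

In this assay, the aryl group on the aromatic carbon between two ring nitrogen atoms proves able to shift the read-out with the hydroxamic acid kept in place: 2-methylphenyl in place of 4-methoxyphenyl gives a number 24.4 percentage points lower from compound 1 to compound 3 (beyond the scatter). Among the compounds shown here, this is the first single-change step, and it shows that a modest but real part of the inhibition at this one concentration depends on this aryl group. No measurement on hand accounts for the change.

The compounds shown leave open whether the difference follows the loss of the methoxy group, the arrival of the methyl group or the change in where the group sits on the phenyl ring, which 4-methylphenyl and 2-methoxyphenyl would help to separate. They also leave open how an amine or a carboxylic acid on that phenyl ring would read in this assay.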